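A few compounds are considered here, and "the series" means these few. Any claim that something is new, unique, unknown or untested is made for them only; others in the source may bear on it.

Measured so far:
- compound 1 `CCNCCCCNCCCCNCCCCN` gives 1100 nM in a functional assay on L1210 cells (Mus musculus) for inhibition; a lower number here means a stronger inhibitor, a higher number a weaker inhibitor
- compound 2 `CCNCCCCNCCCCNCCCCNC(C)(C)C` gives 3000 nM in this assay

Within the data shown here, compound 2 holds the higher of the two numbers, and compound 1 is its only neighbour. Compound 3 `CC(C)(C)NCCCCNCCCCNCCCCNC(C)(C)C` has not yet been measured. It differs from compound 2 by tert-butyl in place of ethyl on an amine nitrogen and so carries the same group twice.

Among the measured compounds shown here, one measured step bears on this change: a 2.7-fold higher number from compound 1 to compound 2 (0.44 log units; beyond the scatter) with tert-butyl in place of hydrogen on an amine nitrogen. That step brought in the same group but replaced hydrogen rather than ethyl, so it is only a loose guide. A further modest rise in the number is expected in this assay and no reversal. The estimated step is a 2.2-fold higher number from compound 2 to compound 3 (0.34 log units; beyond the scatter) and it remains uncertain. For compound 3 the expected value is 6500 nM with an estimated range of 2500 nM to 16000 nM in this assay for now.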

Compound 3, inhibition constant: 56000 nM
Compound 3: middle estimate off by 8.6-fold (0.94 log units), on the low side; measured number above the stated range.
By their numbers in this assay, from the lowest: compound 1; then compound 2; then compound 3.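

In this assay, tert-butyl in place of ethyl on an amine nitrogen gives a 19-fold higher number from compound 2 to compound 3 (1.27 log units; beyond the scatter), a large step beside the modest 2.7-fold higher number from compound 1 to compound 2 (0.44 log units; beyond the scatter), where the same group replaced hydrogen. The entry of tert-butyl therefore has no fixed size of effect in these compounds: the second tert-butyl, replacing ethyl, costs far more than the first, and compound 3, which carries the group twice, has the highest number of the three. No measurement shown here accounts for the size of this step.

As far as these compounds go, it remains open whether isopropyl or a longer chain such as n-butyl on this nitrogen would give a gradual or an abrupt rise from ethyl. Also open, from the compounds shown here alone, is how hydrogen at this nitrogen would read with tert-butyl kept on the other terminal amine.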